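The source may report more compounds than this note shows. Statements on the series, on what has been measured and on what is new or still open speak of the compounds shown alone.

Working notes on the series, all read in a functional assay on KYSE-410 cells (Homo sapiens) for antiproliferative activity, read by MTT assay, with a stated time of 72 h; a higher number here means a weaker inhibitor, a lower number a stronger inhibitor. Compound 1 `O=C(Nc1cccc(F)c1)c1cc(=O)[nH]c2cc(-c3ccccc3)ccc12` gives > 20000 nM, which is a limit and not a number. Compound 2 `Cc1cc(-c2ccc3c(C(=O)Nc4cccc(F)c4)cc(=O)[nH]c3c2)c(C)cc1F` gives > 20000 nM, which is also a limit. Going by the values given here, compound 3 `C=Cc1ccc2c(C(=O)Nc3cccc(F)c3)cc(=O)[nH]c2c1` gives 13600 nM, the only true number among the three values so far.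

The next change leads to compound 4 `C#Cc1ccc2c(C(=O)Nc3cccc(F)c3)cc(=O)[nH]c2c1`: ethynyl in place of vinyl on an aromatic carbon. Ethynyl takes the place of vinyl on an aromatic carbon of a six-membered aromatic ring of carbon only, part of a fused or bridged system of two rings.

Among the compounds with values here, two measured steps touch this position, an at least 1.4-fold lower number from compound 1 to compound 3 (0.16 log units; that floor lies within the scatter) and an at least 1.4-fold lower number from compound 2 to compound 3 (0.16 log units; that floor lies within the scatter). Both replace a larger aryl group with vinyl, and both are floors rather than full sizes. The step that the two limits leave unreadable from compound 1 to compound 2 adds nothing on size. Within the data shown here, no measured step starts from vinyl, so the data give no direction for replacing it with ethynyl, and no shift beyond the scatter is expected in this assay.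

The expected step is a 1.1-fold lower number from compound 3 to compound 4 (0.05 log units; within the scatter). For compound 4 the estimated value is 12000 nM, with an expected range from 5000 nM to 20000 nM.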

Compound 4, half-maximal inhibitory concentration: 9700 nM
For compound 4 the middle estimate is 1.2-fold (0.09 log units) above the measured one; the measured number falls inside the stated range.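

In this assay the change from vinyl to ethynyl gives a 1.4-fold lower number from compound 3 to compound 4 (0.15 log units; within the scatter), so the double and the triple bond on this aromatic carbon cannot be told apart at this level. Ethynyl is the first group here whose steps from the two aryl groups clear the scatter, with an at least 2.0-fold lower number from compound 2 to compound 4 (0.31 log units; beyond the scatter) and an at least 2.0-fold lower number from compound 1 to compound 4 (0.31 log units; beyond the scatter), whereas the matching floors for vinyl stayed within it. These two steps are floors and not full sizes because compound 1 and compound 2 each sit at a limit of the assay, not at a number: the limit of > 20000 nM in this assay, at which 2 of the 4 values shown sit.

The compounds shown carry only aryl groups and two-carbon groups with a double or triple bond at this position, so it stays open whether a nitrile, an amine or a longer chain such as propyl would move the number beyond the scatter from compound 4. All four compounds also share the same fluorophenyl amide and the same core, so the data say nothing on how a change elsewhere, such as a carboxylic acid on that phenyl ring, would read in this assay.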